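Series notes: silicon-bearing ether chain replaced by methylsulfonyl

The compounds below may be only part of what the source reports. "The series", "measured", "known", "first", "only" and "open" are said of these compounds alone.

Among the measured compounds shown here, compound 1 `C[n+]1ccn(COCC[Si](C)(C)C)c1/C=N/O` is the only member of the series with a number in a physicochemical assay for lipophilicity; a lower number here means a more polar compound, a higher number a more lipophilic compound: there compound 1 gives -0.34. Compound 2 `C[n+]1ccn(CC[N+](=O)[O-])c1/C=N/O` belongs to the same set, but in this assay compound 2 gives no result reported, so compound 1 stands alone as the reference point. Compound 3 `C[n+]1ccn(COCCS(C)(=O)=O)c1/C=N/O` is not yet measured. It differs from compound 1 as follows: a group of 4 heavy atoms (1 carbon, 2 oxygen, 1 sulfur; no ring) in place of a group of 4 heavy atoms (3 carbon, 1 silicon; no ring), on a saturated chain carbon, two bonds along the chain from an oxygen on a saturated carbon, in words a group of 4 heavy atoms (1 carbon, 2 oxygen, 1 sulfur; no ring) in place of a group of 4 heavy atoms (3 carbon, 1 silicon; no ring), on a saturated chain carbon, two bonds along the chain from an oxygen on a saturated carbon. For the measured compounds named here, no measured pair shows such a swap, so the step is an expectation only: for compound 3 a large downward step, well beyond the usual scatter, is expected, a number 2.26 log units lower from compound 1 to compound 3 (beyond the scatter). Compound 3 is accordingly estimated at -2.6 in this assay, with a range from -3.6 to -1.6.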

Compound 3, distribution coefficient: < -3.3
Compound 3 was reported as a limit; the forecaster's own chance of this, stated with the estimate: 20%; middle value at least 0.70 log units away from the limit.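

In this assay compound 3 gives < -3.3, which is a limit of the assay and not a number. Among the compounds shown here, on a saturated chain carbon, two bonds along the chain from an oxygen on a saturated carbon, methylsulfonyl in place of the group of 3 carbon and 1 silicon atoms gives a number at least 2.96 log units lower from compound 1 to compound 3 (beyond the scatter), the first measured change and evidence that a swap at this chain end can move the read-out strongly. This step remains a bound and not a size, because the reading of compound 3 ends at a limit: the limit of < -3.3 in this assay, at which 1 of the 3 values shown sits.

For the compounds shown here, with only this one swap at the position, the share of the step tied to the leaving group and the share tied to methylsulfonyl cannot be separated. On these data alone, how a tert-butyl group, an amine or a carboxylic acid would read at this chain end in this assay stays open.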